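The source may report more compounds than this note shows. Statements on the series, on what has been measured and on what is new or still open speak of the compounds shown alone.

Within the data shown here, compound 1 `Cc1ncc([N+](=O)[O-])n1CCSc1nnc(-c2ccc(Cl)cc2)o1` is one of only two compounds so far measured in a functional assay on SGC-7901 cells (Homo sapiens) for cytotoxicity, read by MTT assay, with a stated time of 48 h (a higher number here means a weaker inhibitor, a lower number a stronger inhibitor), where compound 1 gives 31900 nM. Its companion, compound 2 `Cc1ncc([N+](=O)[O-])n1CCSc1nnc(-c2ccc(N(C)C)cc2)o1`, gives 32800 nM in this assay, and the step of a 1.0-fold higher number from compound 1 to compound 2 (0.01 log units; within the scatter) leaves the two compounds at one level, with no separation that the measurement can support. Compound 1 therefore stands together with compound 2, neither ahead of nor behind it.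

Compound 3 `Cc1ncc([N+](=O)[O-])n1CCSc1nnc(-c2ccnc(Cl)c2)o1` has not yet been measured. It differs from compound 1 in one place: 2-chloropyridin-4-yl in place of 4-chlorophenyl on an aromatic carbon. Among the measured compounds shown here, the single measured step concerns a different kind of change, a group on the outer ring rather than the ring itself, so nothing measured speaks directly to this exchange. What the step from compound 1 to compound 2 does show is that the outer ring accepts a change without moving the number in this assay, and on that slender basis no step beyond the scatter is expected here.

Compound 3 is therefore expected to give 35000 nM in this assay, within a range of 15000 nM to 80000 nM, a step of a 1.1-fold higher number from compound 1 to compound 3 (0.04 log units; within the scatter).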

Compound 3, half-maximal inhibitory concentration: 32300 nM
For compound 3 the middle estimate is 1.1-fold (0.03 log units) above the measured one, within the range that was stated.
By their numbers in this assay, from the lowest: compounds 1, 3 and 2 (each within the scatter of the next).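

In this assay the exchange of 4-chlorophenyl for 2-chloropyridin-4-yl on this aromatic carbon gives a 1.0-fold higher number from compound 1 to compound 3 (0.01 log units; within the scatter) and so leaves the two compounds at one level, which shows that the ring standing at this position can itself be exchanged, and not only a group carried on it. The earlier comparison covered only dimethylamino in place of chloro, with a 1.0-fold higher number from compound 1 to compound 2 (0.01 log units; within the scatter) as its step, whereas here a ring of carbon only gives way to a ring with 1 hetero atom and 1 hydrogen-bond acceptor, and the number still stays within the scatter. No measurement at hand bears on why these compounds stand at one level.

The compounds shown all carry a six-membered aromatic ring at this position, so it stays open whether a carboxylic acid or a primary amine on that ring, or a piperidine in place of it, would separate from compound 1 in this assay. On these data alone, it also stays open whether any change in the shared core, such as a longer chain in its linking part, would move the number when the outer ring has not done so.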